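Neopentyl for tert-butyl carried onto a second core

This account rests on a few compounds, and the source may have more. Where it says the series, first, only, none or still open, it means among the compounds named here.

Measured compounds:
Compound 1, `CC(C)(C)C[C@@H](O)C(=O)N1N=CC[C@H]1C(=O)NCc1cc(Cl)ccc1-n1cnnn1`, 590 nM
Compound 2, `CC(C)(C)[C@@H](O)C(=O)N1N=CC[C@H]1C(=O)NCc1cc(Cl)ccc1-n1cnnn1`, 1400 nM
Compound 3, `CC(C)(C)[C@@H](O)C(=O)N1[C@H](C(=O)NCc2cc(Cl)ccc2-n2cnnn2)C[C@@H]2C[C@@H]21`, 1500 nM

The three measured compounds were tested in a functional assay on a cell-free system (plasma, Homo sapiens), with a stated time of 3 min; a lower number here means a stronger inhibitor, a higher number a weaker inhibitor. Compound 1 gives 590 nM, compound 2 gives 1400 nM and compound 3 gives 1500 nM in this assay. Compounds 1 and 2 share one core and differ in one place: neopentyl in place of tert-butyl on a saturated chain carbon bound to a carbonyl carbon and an oxygen on a saturated carbon. That change gave a 2.4-fold lower number from compound 2 to compound 1 (0.38 log units; beyond the scatter), a modest step that is nonetheless beyond the scatter. Compound 3 has the highest number of the three, but its value and that of compound 2 lie within the scatter of each other, so no order between them is claimed; the difference between the core of compound 3 and the core of compound 2 is not broken down here.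

Compound 4, `CC(C)(C)C[C@@H](O)C(=O)N1[C@H](C(=O)NCc2cc(Cl)ccc2-n2cnnn2)C[C@@H]2C[C@@H]21`, has not yet been measured. It stands to compound 3 as compound 1 stands to compound 2: neopentyl in place of tert-butyl on a saturated chain carbon bound to a carbonyl carbon and an oxygen on a saturated carbon. The place of the change is the same in both pairs, so this is the same change made on a second core. For the measured compounds named here, since the only precedent for it is a 2.4-fold lower number from compound 2 to compound 1 (0.38 log units; beyond the scatter), and since compound 3 has a starting value of 1500 nM, a step of similar size is expected, giving a 2.4-fold lower number from compound 3 to compound 4 (0.38 log units; beyond the scatter) as the estimate. Going by the values given here, the single precedent gives little to judge how well the step carries over, so the range is kept wide. Compound 4 is therefore estimated at 620 nM, between 350 nM and 1200 nM, in this assay.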

Compound 4, half-maximal inhibitory concentration: 570 nM
For compound 4 the middle estimate is 1.1-fold (0.04 log units) above the measured one, within the range that was stated.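

In this assay, neopentyl in place of tert-butyl gave a 2.6-fold lower number from compound 3 to compound 4 (0.42 log units; beyond the scatter), a modest step but one beyond the scatter, and in the same direction as the step seen on the core of compound 1. Set beside that earlier step, the change carried from one core to the other with no difference in size that can be told apart: the same change on two cores in this assay, a 2.4-fold lower number (0.38 log units; beyond the scatter) from compound 2 to compound 1 and a 2.6-fold lower number (0.42 log units; beyond the scatter) from compound 3 to compound 4, 1.1-fold (0.04 log units) apart, within the scatter of two such steps. This shows that, for these two pairs and in this one assay, the step held on both cores, but two pairs cannot establish a rule for the series, and they say nothing about a third core, about any other read-out or about why the number falls.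

The compounds shown leave open whether the trend continues with a longer chain than neopentyl, or whether a cyclohexyl group at the same place on the saturated chain carbon would give a step of similar size. They also leave open whether an amine in place of the hydroxyl would keep the step on either core, and whether changes elsewhere in these molecules would alter how well the neopentyl step carries over.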